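A few compounds are considered here, and "the series" means these few. Any claim that something is new, unique, unknown or untested is made for them only; others in the source may bear on it.

Measured compounds in an assay on isolated protein for inhibition of Nitric oxide synthase, inducible (Homo sapiens), read by scintillation counting, with a stated time of 30 min, tested at 50 uM; on this read-out lower numbers stand for less inhibition and higher numbers for more inhibition at the one concentration tested (going by the name of the read-out):
- compound 1 `CCC(=O)N1N=C(c2cc(OC)ccc2N)SC1(C)C` gives 73%
- compound 2 `CCC(=O)N1N=C(c2cc(Cl)ccc2N)SC1(C)C` gives 1.07%
- compound 3 `CC1(C)SC(c2cc(Cl)ccc2N)=NN1C(=O)C1CC1` gives 23.2%

Compound 2 stands lowest of the three; the step of a number 71.9 percentage points lower from compound 1 to compound 2 (beyond the scatter) is large, and the step of a number 22.1 percentage points higher from compound 2 to compound 3 (beyond the scatter) is modest. Compound 4 `CCC(=O)N1N=C(c2ccccc2N)SC1(C)C` has not been measured; it differs from compound 2 by hydrogen in place of chloro on an aromatic carbon. Within the data shown here, only the step from compound 1 to compound 2 bears on this position, and it shows that the group on that aromatic carbon moves this assay strongly. Hydrogen is neither methoxy nor chloro, so the direction is uncertain; a rise from the low value of compound 2 is expected, of size a number 18.9 percentage points higher from compound 2 to compound 4 (beyond the scatter). Compound 4 is therefore estimated at 20%, with a range of 0% to 50%.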

Compound 4, a percentage reported as inhibition, at one concentration (the size of the read-out at that concentration, not a potency): 19.2%
Compound 4: middle estimate off by 0.8 percentage points, on the high side, within the range that was stated.
By their numbers in this assay, from the lowest: compound 2; then compounds 4 and 3 (each within the scatter of the next); then compound 1.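

Hydrogen gives this position a reference point in this assay, on the aromatic carbon para to an amino group: a number 18.1 percentage points higher from compound 2 to compound 4 (beyond the scatter), while a number 53.8 percentage points lower from compound 1 to compound 4 (beyond the scatter). Relative to hydrogen, chloro goes with a lower number and methoxy with a higher one, so both groups contribute to the contrast seen earlier. The earlier compounds shown here could show only that contrast, not how each group stood against hydrogen.

The data offer no explanation for this order. Open, going by these compounds, is whether ethoxy, methyl, fluoro or a dimethylamino group at this carbon would stand nearer methoxy or chloro, and whether the order holds with cyclopropyl on the carbonyl carbon.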